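Swapping Methoxy for Trifluoromethyl on Compound 2

This account rests on a few compounds, and the source may have more. Where it says the series, first, only, none or still open, it means among the compounds named here.

Compound 1 `CCOC(=O)c1c(-c2cccc(C(F)(F)F)c2)csc1N` and compound 2 `CCOC(=O)c1c(N)sc(-c2ccc(OC)cc2)c1-c1cccc(C(F)(F)F)c1` share one core, and both were tested in an assay on CHO-K1 cells for displacement of a labelled ligand from adenosine receptor A1 (Homo sapiens), tested at 10 uM; on this read-out higher numbers stand for more inhibition at the one concentration tested (going by the name of the read-out) and lower numbers for less inhibition. In this assay compound 1 gives 93%, while compound 2 gives 81.5%, so compound 2 stands lowest of the two numbers, separated from its nearest neighbour by a number 11.5 percentage points lower from compound 1 to compound 2 (beyond the scatter). Compound 3 `CCOC(=O)c1c(N)sc(-c2ccc(C(F)(F)F)cc2)c1-c1cccc(C(F)(F)F)c1` is compound 2 with a single change: trifluoromethyl in place of methoxy on an aromatic carbon. Among the compounds with values here, no measured pair shows this same change. Within the data shown here, the only measured step, a number 11.5 percentage points lower from compound 1 to compound 2 (beyond the scatter), concerns a 4-methoxyphenyl in place of hydrogen on an aromatic carbon and gives no guide to exchanging a methoxy for a trifluoromethyl. With nothing pointing in either direction, the expected step is a number 3.5 percentage points lower from compound 2 to compound 3 (within the scatter), that is, none beyond the scatter. Compound 3 is therefore estimated at 78%, within a range from 62% to 92%.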

Compound 3, a percentage reported as inhibition, at one concentration (the size of the read-out at that concentration, not a potency): 48.5%
Compound 3: middle estimate off by 29.5 percentage points, on the high side; measured number below the stated range.
By their numbers in this assay, from the lowest: compound 3; then compound 2; then compound 1.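

In this assay, the group carried on the added phenyl ring clearly matters: trifluoromethyl in place of methoxy gives a number 33 percentage points lower from compound 2 to compound 3 (beyond the scatter) and counts as a large step. Compound 2 alone had shown only a modest loss against the hydrogen of compound 1, whereas 4-(trifluoromethyl)phenyl in place of that hydrogen gives a number 44.5 percentage points lower from compound 1 to compound 3 (beyond the scatter), so the loss here depends on what the phenyl ring carries and not merely on its presence. Nothing measured here explains why these two groups differ so much.

From the compounds shown here alone, it remains open whether the gap reflects something methoxy contributes, something trifluoromethyl takes away, or both. A plain phenyl ring, or one carrying a hydroxyl, an amine or a chlorine at the same place, would help separate these possibilities.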